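Swapping the sulfonyl ring for a methoxy-dimethylphenyl group

The source may hold more compounds than are shown below. What is called first, only, known or untested is meant among the compounds shown, and "the series" means these compounds.

Compound 3 `CN1CCC(N(C)C(=O)C2CN(S(=O)(=O)C3=CC4CCOC4C=C3)c3ccccc32)CC1` gives 31.6 nM in a functional assay on CHO cells for antagonist activity at 5-hydroxytryptamine receptor 6 (Homo sapiens), read by FLIPR (a higher number here means a weaker inhibitor, a lower number a stronger inhibitor), the second highest of three numbers. Compound 2 `COc1ccc(S(=O)(=O)N2CC(C(=O)N3CC(CN)C3)c3ccccc32)c2ccccc12` gives 79.4 nM, and compound 1 `COc1ccc(S(=O)(=O)N2CC(C(=O)N(C)C3CCN(C)CC3)c3ccccc32)c2ccccc12` gives 7.94 nM. Compound 4 `COc1ccc(S(=O)(=O)N2CC(C(=O)N(C)C3CCN(C)CC3)c3ccccc32)c(C)c1C` differs from compound 3 by a group of 10 heavy atoms (9 carbon, 1 oxygen; one six-membered aromatic ring of carbon only) in place of a group of 9 heavy atoms (8 carbon, 1 oxygen; one five-membered non-aromatic ring with 1 hetero atom, one six-membered non-aromatic ring of carbon only), on a sulfonyl sulfur. Among the measured compounds shown here, the only step on record, a 10-fold higher number from compound 1 to compound 2 (1.00 log units; beyond the scatter), alters the amide, not the sulfonyl group, so no measured step bears directly on this change. Compound 1 and compound 3 share the amide and differ only at the sulfonyl group; their two values show a lower number for compound 1. A lower number is expected for compound 4 because compound 1, which also carries a methoxy-bearing aromatic ring, gives 7.94 nM. The expected step is a 2.6-fold lower number from compound 3 to compound 4 (0.42 log units; beyond the scatter). For compound 4 the estimate is 12 nM, within 3 nM to 50 nM.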

Compound 4, inhibition constant: 100 nM
Estimate against measurement, compound 4: 8.3-fold (0.92 log units) below, and the stated range ends below it.
By their numbers in this assay, from the lowest: compound 1; then compound 3; then compounds 2 and 4 (each within the scatter of the next).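

The sulfonyl sulfur is sensitive to the group it carries: with the amide unchanged, placing 4-methoxy-2,3-dimethylphenyl there gives a 3.2-fold higher number from compound 3 to compound 4 (0.50 log units; beyond the scatter) in this assay. A methoxy-bearing aromatic ring alone therefore does not secure a low number: compound 1 gives 7.94 nM while compound 4, with the same amide, gives 100 nM on this scale. No measurement shown here explains the change.

Still open, going by these compounds, is how the ring behaves with a single methyl, or with chlorine or a nitrile replacing the methoxy. On these data alone, it is also open whether 4-methoxy-2,3-dimethylphenyl behaves the same way alongside the 3-(aminomethyl)azetidin-1-yl amide.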